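From methylamino to methyl, with the ethynyl group kept

This account rests on a few compounds, and the source may have more. Where it says the series, first, only, none or still open, it means among the compounds named here.

For the measured compounds named here, in a functional assay on K562 cells (Homo sapiens), read by MTT assay, with a stated time of 72 h (a higher number here means a weaker inhibitor, a lower number a stronger inhibitor), compound 3 `C#Cc1cn([C@@H]2O[C@H](CO)[C@@H](O)[C@H]2O)c2ncnc(NC)c12` gives 1380 nM, the lowest number among the compounds measured so far. Compound 1 `CNc1ncnc2c1c(-c1ccco1)cn2[C@@H]1O[C@H](CO)[C@@H](O)[C@H]1O` gives 15100 nM. Compound 2 `CNc1ncnc2c1c(-c1cc3ccccc3o1)cn2[C@@H]1O[C@H](CO)[C@@H](O)[C@H]1O` gives > 20000 nM, which is a limit of the assay and not a number.

Compound 4 `C#Cc1cn([C@@H]2O[C@H](CO)[C@@H](O)[C@H]2O)c2ncnc(C)c12` keeps the ethynyl group of compound 3 but has methyl in place of methylamino on an aromatic carbon.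

The measured steps all concern the other substituent. The change to ethynyl gives an 11-fold lower number from compound 1 to compound 3 (1.04 log units; beyond the scatter) and an at least 14-fold lower number from compound 2 to compound 3 (1.16 log units; beyond the scatter), both large, whereas the change from furan-2-yl to 1-benzofuran-2-yl gives an at least 1.3-fold higher number from compound 1 to compound 2 (0.12 log units; that floor lies within the scatter), a floor that lies within the scatter. None of these steps alters the methylamino group, so none gives a direct size for the change at hand. They do show that a single change elsewhere on the shared core can move the number in this assay substantially, which argues for a wide range. With no measured basis for a direction, the estimate stays close to compound 3 at 1380 nM. The expected result is a 1.4-fold lower number from compound 3 to compound 4 (0.14 log units; within the scatter), with no shift beyond the scatter as the central expectation. For compound 4 the estimated value is 1000 nM, with an expected range of 150 nM to 7000 nM.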

Compound 4, half-maximal inhibitory concentration: 110 nM
For compound 4 the middle estimate is 9.1-fold (0.96 log units) above the measured one; the measured number lies below the stated range.
By their numbers in this assay, from the lowest: compound 4; then compound 3; then compound 1. At a limit, above all of these: compound 2.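

In this assay, methyl in place of methylamino gives a 13-fold lower number from compound 3 to compound 4 (1.10 log units; beyond the scatter). For the compounds shown here, this is the first measured step at this position, an aromatic carbon next to the ring nitrogen, and it shows that the group there can move the number by a large step, as the other substituent did when the change to ethynyl gave an 11-fold lower number from compound 1 to compound 3 (1.04 log units; beyond the scatter). The step replaces a group counted with a hydrogen-bond donor and a hydrogen-bond acceptor by one counted with neither, but a single pair cannot tie the result to those counts, and nothing measured here gives a cause for it.

Going by these compounds alone, only one pair carries this change, so it remains open whether methyl would give a similar step in place of methylamino with furan-2-yl or 1-benzofuran-2-yl on the shared core. On these data alone, it also remains open how an unsubstituted amine, an ethyl chain or a methoxy group at this position would compare with methyl and methylamino in this assay.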